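Gem-dimethyl variant of compound 2: stability outlook

The compounds below may be only part of what the source reports. "The series", "measured", "known", "first", "only" and "open" are said of these compounds alone.

The series shares one core, seen in compound 1 `COCCn1cc(C(=O)C(=O)Nc2ccc(OC(C)C)nc2)c2ccccc21` and compound 2 `COCC(C)n1cc(C(=O)C(=O)Nc2ccc(OC)nc2)c2ccccc21`; the two differ in the chain on the aromatic nitrogen and in the ether on the outer ring. In an ADME assay on liver (Mus musculus, strain CD-1) for metabolic stability, read by LC-MS, using microsomes and NADPH, with a stated time of 5 min, tested at 1 uM (a higher number here means that the compound lasts longer, a lower number that the compound disappears faster), compound 1 gives 1.65 h, while compound 2 gives 0.267 h. Compound 2 therefore holds the lowest number of the two measured, and the gap to compound 1 lies beyond the scatter. For the measured compounds named here, no single-change step between measured compounds exists, so nothing here tells how a change at the chain alone moves the half-life.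

Compound 3 `COCC(C)(C)n1cc(C(=O)C(=O)Nc2ccc(OC)nc2)c2ccccc21` is the unmeasured follow-up to compound 2. Its difference from compound 2 is methyl in place of hydrogen on a saturated chain carbon bound to an aromatic nitrogen and two saturated chain carbons. For this step the expected size in this assay is a modest rise, at most just beyond the scatter and possibly within it, as the expected step of a 1.7-fold higher number from compound 2 to compound 3 (0.23 log units; within the scatter) shows. Compound 3 is thus estimated to give 0.45 h in this assay, with a range from 0.18 h to 1.1 h.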

Compound 3, half-life: 0.267 h
Compound 3: the middle estimate sits 1.7-fold (0.23 log units) above what was measured; the measured number falls inside the stated range.
By their numbers in this assay, from the lowest: compounds 2 and 3 (each within the scatter of the next); then compound 1.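

In this assay, for the compounds shown here, the change from 1-(methoxymethyl)ethyl to 1-(methoxymethyl)-1-methylethyl reads no change at the digits printed from compound 2 to compound 3 (within the scatter), and this is the first single-change reading at the chain on the aromatic nitrogen. Methyl in place of hydrogen on this saturated chain carbon therefore leaves the half-life of this pair unmoved, so the chain can take this extra carbon with no visible effect on the number, at least with the methoxy ether on the outer ring held fixed. Nothing at hand bears on why the step reads this way.

Going by these compounds, the gap between compound 1 and compound 2 remains unassigned, since those two differ at both the chain and the ether on the outer ring, and the part played by each change alone stays unknown. Also open, on these data alone, is whether a larger change at the same chain, such as an ethyl group on that saturated chain carbon or an amine in place of the methoxy end, would move the half-life where methyl does not.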